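The compounds below may be only part of what the source reports. "The series", "measured", "known", "first", "only" and "open" are said of these compounds alone.

Working notes on the series. Among the compounds with values here, compound 1 `COC(=O)C1=C(C)NC(c2nccs2)=NC1(C)c1ccc(C#N)cc1` and compound 2 `COC(=O)C1=C(CN2CCC(O)CC2)NC(c2nccs2)=NC1(C)c1ccc(F)cc1` share the core and differ at more than one place, so no single step between them is counted. In a physicochemical assay for solubility, read by HPLC, in phosphate buffer, at pH 6.5 (a lower number here means a less soluble compound, a higher number a more soluble compound), compound 1 gives 87 ug/mL and compound 2 gives 593 ug/mL, the higher of the two numbers shown, and the gap between them lies beyond the scatter. The two values therefore stand on their own. Compound 3 `COC(=O)C1=C(CN(C)C2(C(=O)O)CC2)NC(c2nccs2)=NC1(C)c1ccc(F)cc1` differs from compound 2 by a group of 8 heavy atoms (5 carbon, 1 nitrogen, 2 oxygen; one three-membered non-aromatic ring of carbon only) in place of a group of 7 heavy atoms (5 carbon, 1 nitrogen, 1 oxygen; one six-membered non-aromatic ring with 1 hetero atom), on a saturated chain carbon bound to a double-bonded ring carbon. Within the data shown here, no measured pair here shows what such a change does in this assay, so the expectation rests on compound 2 alone. Compound 3 is expected to stay near or somewhat above compound 2 in this assay. The expected step is a 1.3-fold higher number from compound 2 to compound 3 (0.10 log units; within the scatter), small and upward if anything, not confidently beyond the scatter. Compound 3 is estimated at 750 ug/mL, with a range from 250 ug/mL to 2000 ug/mL.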

Compound 3, solubility: > 510 ug/mL
Compound 3 was reported as a limit; the forecaster's own chance of this, stated with the estimate: 10%; the middle value lies beyond the limit too.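

In this assay, within the data shown here, compound 3 gives > 510 ug/mL, which is a limit and not a number, so no step from compound 2 to compound 3 can be read. The compounds shown leave open whether compound 3 differs from compound 2 in this assay beyond the scatter.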